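Chloro for Bromo on a Tolerated Tetrazole Series

The compounds below may be only part of what the source reports. "The series", "measured", "known", "first", "only" and "open" are said of these compounds alone.

Measured compounds:
- compound 1 `CC1(c2ccc(Nc3nc(N4CCCc5ccccc54)nc(N4CCCc5ccccc54)n3)cc2)NC(=O)c2ccccc2N1`: "not determined" (no result reported)
- compound 2 `CC1(c2ccc(NC(c3ccc(Br)cc3)c3nnnn3C3CCCCC3)cc2)NC(=O)c2ccccc2N1`: > 400000 nM
- compound 3 `Nc1nc(-c2ccccc2)cc(-c2ccc(C3NC(=O)c4ccccc4N3)cc2)n1`: "not determined" (no result reported)

Three compounds have been examined in an ADME assay on Vero cells (Chlorocebus sabaeus) for cytotoxicity, read by MTT assay, with a stated time of 72 h; a lower number here means that less compound is tolerated, a higher number that more compound is tolerated. For compound 1 and compound 3 no result was reported. On these data alone, compound 2 gives only a limit of the assay, > 400000 nM, so its true value is unknown. Among the measured compounds shown here, it therefore sits at the limit of > 400000 nM in this assay, at which 1 of the 3 values shown sits, and no step between measured compounds can be drawn from these entries.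

Compound 4 `CC1(c2ccc(NC(c3ccc(Cl)cc3)c3nnnn3C3CCCCC3)cc2)NC(=O)c2ccccc2N1` differs from compound 2 by chloro in place of bromo on an aromatic carbon. For the measured compounds named here, with no measured step available, the change is small and is expected to move the read-out by no more than the usual scatter, in no particular direction. Compound 4 is therefore estimated at 400000 nM, within 200000 nM to 800000 nM, a step of a number no higher from compound 2 to compound 4 (the limit leaves the size open).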

Compound 4, half-maximal cytotoxic concentration: > 400000 nM
Compound 4: a limit, no number (the forecaster's own chance of this, stated with the estimate: 85%); the middle value lies on the limit itself.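

In this assay compound 2 and compound 4 both give only a limit, so no step between them can be read: the limit of > 400000 nM in this assay, at which 2 of the 4 values shown sit.

On these data alone, the true tolerated concentration of each compound, and whether chloro in place of bromo changes it, stay open.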